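Swapping the Sulfonyl Arm for a Carbonyl Arm

The source may hold more compounds than are shown below. What is called first, only, known or untested is meant among the compounds shown, and "the series" means these compounds.

Compound 3 `COc1cc(N(Cc2nc3ccccc3[nH]2)S(=O)(=O)c2ccccc2Cl)cc(OC)c1OC` gives the highest number of the three measured compounds in a functional assay on MCF7 cells (Homo sapiens) for inhibition, read by MTT assay, with a stated time of 48 h; on this read-out lower numbers stand for stronger inhibition and higher numbers for weaker inhibition: compound 3 gives 38100 nM. Compound 1 `COc1cc(N(Cc2nc3ccccc3[nH]2)S(=O)(=O)c2ccc(F)cc2)cc(OC)c1OC` gives 9380 nM in this assay, and compound 2 `COc1cc(N(Cc2nc3ccccc3[nH]2)S(=O)(=O)c2ccc(Br)cc2)cc(OC)c1OC` gives 7740 nM. The step of a 1.2-fold lower number from compound 1 to compound 2 (0.08 log units; within the scatter) stays within the scatter, whereas a 4.1-fold higher number from compound 1 to compound 3 (0.61 log units; beyond the scatter) and a 4.9-fold higher number from compound 2 to compound 3 (0.69 log units; beyond the scatter) are both beyond it.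

Compound 4 `COc1cc(N(Cc2nc3ccccc3[nH]2)C(=O)c2ccc(C)cc2)cc(OC)c1OC` changes compound 3 in one place: (4-methylphenyl)carbonyl in place of (2-chlorophenyl)sulfonyl on a nitrogen on an aromatic ring. Among the measured compounds shown here, no measured step covers this change directly. For the measured compounds named here, the two steps that bear on it, a 4.1-fold higher number from compound 1 to compound 3 (0.61 log units; beyond the scatter) and a 4.9-fold higher number from compound 2 to compound 3 (0.69 log units; beyond the scatter), show only that the 2-chlorophenyl group on the sulfonyl sulfur goes with a higher number than a 4-fluorophenyl or a 4-bromophenyl group. Going by the values given here, compound 4 returns to an aromatic ring carrying its group at the 4-position of the phenyl, but joined through a carbonyl rather than a sulfonyl, and no measured pair speaks to that exchange. The estimate for compound 4 in this assay is therefore 10000 nM, within a range from 3000 nM to 40000 nM. For compound 4 this estimate means an expected step of a 3.8-fold lower number from compound 3 to compound 4 (0.58 log units; beyond the scatter), held with wide uncertainty.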

Compound 4, half-maximal inhibitory concentration: 49300 nM
Compound 4: the middle estimate sits 4.9-fold (0.69 log units) below what was measured, and the stated range ends below it.
By their numbers in this assay, from the lowest: compounds 2 and 1 (each within the scatter of the next); then compounds 3 and 4 (each within the scatter of the next).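

At this nitrogen in this assay the (4-methylphenyl)carbonyl group gives a 1.3-fold higher number from compound 3 to compound 4 (0.11 log units; within the scatter) when it replaces (2-chlorophenyl)sulfonyl, so this carbonyl arm reads level with the 2-chlorophenyl arm. Set against the other two sulfonyl arms it gives a 6.4-fold higher number from compound 2 to compound 4 (0.80 log units; beyond the scatter) and a 5.3-fold higher number from compound 1 to compound 4 (0.72 log units; beyond the scatter) and so does not reach the numbers of the (4-bromophenyl)sulfonyl and (4-fluorophenyl)sulfonyl compounds. Nothing available here explains this outcome.

Compound 4 changes the linking group and the ring's substituent in a single exchange, so the compounds shown cannot separate the two; a (4-methylphenyl)sulfonyl or a (2-chlorophenyl)carbonyl arm would form the pairs that could. Also open, on these data alone, is how an acetyl group on this nitrogen, with no aromatic ring in the arm, would read.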